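Thiophene to Phenyl on the Amide of Compound 1

The source may report more compounds than this note shows. Statements on the series, on what has been measured and on what is new or still open speak of the compounds shown alone.

Compound 1 `COc1ccc(S(=O)(=O)N2CCc3cccc(NC(=O)c4cccs4)c32)cc1` gives 54 nM in a functional assay on TSGH 9201 cells (Homo sapiens) for cytotoxicity (on this read-out lower numbers stand for stronger inhibition and higher numbers for weaker inhibition), the higher of the two numbers recorded so far, and compound 2 `COc1ccc(S(=O)(=O)N2CCc3cccc(NC(=O)c4ccncc4)c32)cc1` gives 10.8 nM. Within the data shown here, the only measured step is a 5.0-fold lower number from compound 1 to compound 2 (0.70 log units; beyond the scatter). That step lies at the same carbonyl carbon. Compound 3 `COc1ccc(S(=O)(=O)N2CCc3cccc(NC(=O)c4ccccc4)c32)cc1` differs from compound 1 by phenyl in place of thiophen-2-yl on a carbonyl carbon. Among the measured compounds shown here, no measured step bears directly on this exchange; the one step recorded shows only that a different ring at this place can move the number modestly. Compound 3 is therefore expected to show a 1.2-fold lower number from compound 1 to compound 3 (0.08 log units; within the scatter), a step within the scatter. The estimate for compound 3 is 45 nM, ranging from 15 nM to 140 nM.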

Compound 3, half-maximal inhibitory concentration: 201 nM
The estimate for compound 3 lay 4.5-fold (0.65 log units) below the measured number; measured number outside the range, above it.
By their numbers in this assay, from the lowest: compound 2; then compound 1; then compound 3.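

Replacing thiophen-2-yl with phenyl on the carbonyl carbon gives a 3.7-fold higher number from compound 1 to compound 3 (0.57 log units; beyond the scatter) in this assay, while replacing pyridin-4-yl with phenyl gives a 19-fold higher number from compound 2 to compound 3 (1.27 log units; beyond the scatter). Ring size alone therefore does not set the number, as phenyl and pyridin-4-yl, both six-membered aromatic rings, stand at opposite ends of the three compounds. Nothing measured here gives a reason for these steps. Still open, as far as these compounds go, is how a saturated ring such as piperidine, or an amine on the phenyl ring, would stand at this carbonyl carbon.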